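The compounds below may be only part of what the source reports. "The series", "measured", "known", "first", "only" and "open" are said of these compounds alone.

Measured so far in an ADME assay on microsomes from liver (Homo sapiens) for metabolic stability, read by LC-MS, using NADPH, tested at 5 uM; on this read-out lower numbers stand for a shorter-lived compound and higher numbers for a longer-lived compound:
Compound 1 `Cc1cc(S(=O)(=O)/N=C(\N)n2nccc2-c2ccccc2)c(SCc2cccc(Cl)c2)cc1Cl` gives 0.309 h in this assay.
Compound 2 `Cc1cc(-c2ccccc2)n(/C(N)=N/S(=O)(=O)c2cc(C)c(Cl)cc2SCc2cccc(Cl)c2)n1` gives 0.205 h in this assay.

Compound 1 and compound 2 give numbers that lie within the scatter of each other, as the one measured step, a 1.5-fold lower number from compound 1 to compound 2 (0.18 log units; within the scatter), shows; on the numbers shown compound 1 therefore stands apart from nothing.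

Compound 3 `Cc1cc(S(=O)(=O)/N=C(\N)n2nccc2-c2ccccc2)c(SCc2ccccc2Cl)cc1Cl` has not yet been measured. It differs from compound 1 by 2-chlorophenyl in place of 3-chlorophenyl on a saturated chain carbon bound to a sulfur. Among the compounds with values here, no measured step moves the chlorine on that ring: the step from compound 1 to compound 2 concerns a methyl on another aromatic carbon and stays within the scatter, so it gives no direction for the change at hand. With nothing in the measured pair pointing either way, the step from compound 1 to compound 3 in this assay is expected to be none beyond the scatter, and compound 3 is expected to give 0.3 h, with a range from 0.13 h to 0.7 h. The step this estimate means is a 1.0-fold lower number from compound 1 to compound 3 (0.01 log units; within the scatter), which is expected to fall within the scatter.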

Compound 3, half-life: 0.226 h
Estimate against measurement, compound 3: 1.3-fold (0.12 log units) above; the measured number falls inside the stated range.
By their numbers in this assay, from the lowest: compounds 2, 3 and 1 (each within the scatter of the next).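

The reading at this position in this assay is that 2-chlorophenyl in place of 3-chlorophenyl on a saturated chain carbon bound to a sulfur comes with a 1.4-fold lower number from compound 1 to compound 3 (0.14 log units; within the scatter). The half-life therefore does not separate the (3-chlorobenzyl)sulfanyl group from the (2-chlorobenzyl)sulfanyl group, so where the chlorine sits on this ring makes no measurable difference among the compounds shown. Nothing available offers a reason for this result.

The compounds shown leave open whether this part of the molecule can shift the half-life at all, since both groups compared keep the same chlorophenyl ring and only the place of the chlorine differs; an amine, a carboxylic acid or a longer chain in place of the chlorobenzyl group would test that more severely. As far as these compounds go, it is also open whether the 2-chlorophenyl group would give the same reading on the methyl-bearing form of the core seen in compound 2, as the two single changes have so far been read only separately from compound 1.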